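This account rests on a few compounds, and the source may have more. Where it says the series, first, only, none or still open, it means among the compounds named here.

Compound 1 `Cn1c(-c2ccc(NC(=O)CCl)cc2)nc(-c2ccccc2)c1-c1ccccc1`: 42.6 ug/mL
Compound 2 `Cn1c(-c2ccc(NC(=O)CN3CCN(c4ccccc4)CC3)cc2)nc(-c2ccccc2)c1-c1ccccc1`: 10.7 ug/mL

Among the measured compounds shown here, in a functional assay on MCF7 cells (Homo sapiens) for cytotoxicity, read by MTT assay, with a stated time of 24 h (on this read-out lower numbers stand for stronger inhibition and higher numbers for weaker inhibition), compound 2 gives the lower of the two numbers, and the only measured step is a 4.0-fold lower number from compound 1 to compound 2 (0.60 log units; beyond the scatter). Compound 3 `COc1ccc(CN2CCN(CC(=O)Nc3ccc(-c4nc(-c5ccccc5)c(-c5ccccc5)n4C)cc3)CC2)cc1` differs from compound 2 by 4-methoxybenzyl in place of phenyl on an amine nitrogen in a ring. For the measured compounds named here, no measured step alters the group on that ring nitrogen; the measured step concerns the chain carbon instead and bears on compound 3 only as a sign that this region tolerates change. A step near or within the scatter is therefore expected, a 1.3-fold lower number from compound 2 to compound 3 (0.10 log units; within the scatter). Compound 3 is estimated at 8.5 ug/mL, with a range of 4 ug/mL to 20 ug/mL.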

Compound 3, half-maximal inhibitory concentration: 80 ug/mL
Compound 3: the middle estimate sits 9.4-fold (0.97 log units) below what was measured; the measured number lies above the stated range.
By their numbers in this assay, from the lowest: compound 2; then compounds 1 and 3 (each within the scatter of the next).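

In this assay the group on the amine nitrogen in the ring matters: 4-methoxybenzyl in place of phenyl brings a 7.5-fold higher number from compound 2 to compound 3 (0.87 log units; beyond the scatter) and so this position does not tolerate every change. The gain seen with 4-phenylpiperazin-1-yl in place of chloro therefore does not carry over to every group on that nitrogen. No measurement on hand explains the size of this step.

Still open, going by these compounds, is whether the step follows the methoxy group or the benzyl link. Benzyl or 4-methoxyphenyl on that nitrogen would separate the two.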